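The source may report more compounds than this note shows. Statements on the series, on what has been measured and on what is new or still open speak of the compounds shown alone.

Compound 1 `Cn1nc(-c2cccnc2)c2ccccc2c1=O` gives 11500 nM in a functional assay (trachea) with Cavia porcellus as the target (on this read-out lower numbers stand for stronger inhibition and higher numbers for weaker inhibition), the second highest of the three numbers in hand, with compound 3 `CCOC(=O)Cn1nc(-c2cccnc2)c2ccccc2c1=O` nearest at 43700 nM and compound 2 `O=c1c2ccccc2c(-c2cccnc2)nn1CC1CCCCC1` furthest at 209 nM. Compound 4 `O=c1c2ccccc2c(-c2cccnc2)nn1CCSc1ncccn1` differs from compound 1 by ((pyrimidin-2-yl)sulfanyl)methyl in place of hydrogen on a saturated chain carbon bound to an aromatic nitrogen. Both known steps bear on this place: a 55-fold lower number from compound 1 to compound 2 (1.74 log units; beyond the scatter) and a 3.8-fold higher number from compound 1 to compound 3 (0.58 log units; beyond the scatter); between those two groups, a 210-fold higher number from compound 2 to compound 3 (2.32 log units; beyond the scatter). A group entering here can therefore move the number strongly either way. The ((pyrimidin-2-yl)sulfanyl)methyl group brings one six-membered aromatic ring, like cyclohexyl, yet also hetero atoms and hydrogen-bond acceptors, like ethoxycarbonyl, so a number below compound 1 but short of compound 2 is expected. For compound 4 the estimate is 1500 nM, range 300 nM to 8000 nM, meaning a 7.7-fold lower number from compound 1 to compound 4 (0.88 log units; beyond the scatter).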

Compound 4, half-maximal inhibitory concentration: 11000 nM
Beside the measured number, compound 4's estimate is 7.3-fold (0.87 log units) below it; measured number outside the range, above it.
By their numbers in this assay, from the lowest: compound 2; then compounds 4 and 1 (each within the scatter of the next); then compound 3.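

Adding ((pyrimidin-2-yl)sulfanyl)methyl at this place gives a 1.0-fold lower number from compound 1 to compound 4 (0.02 log units; within the scatter) in this assay, so compound 1 and compound 4 cannot be told apart. A six-membered aromatic ring in the entering group therefore does not reproduce the low number of compound 2, as a 53-fold higher number from compound 2 to compound 4 (1.72 log units; beyond the scatter) shows, although a 4.0-fold lower number from compound 3 to compound 4 (0.60 log units; beyond the scatter) still favours this group over ethoxycarbonyl. No measurement on hand accounts for these gaps.

Open, going by these compounds, is whether phenyl in place of cyclohexyl would keep the number of compound 2. On these data alone, how an amine or a longer plain carbon chain reads at this place also remains open.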